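Amide side-chain variation on two related saturated cores

The compounds below may be only part of what the source reports. "The series", "measured", "known", "first", "only" and "open" are said of these compounds alone.

Measured so far in a functional assay on A549 cells (Homo sapiens) for antiproliferative activity, read by MTT assay, with a stated time of 72 h; on this read-out lower numbers stand for stronger inhibition and higher numbers for weaker inhibition:
compound 1 `COc1cc2ncnc(N3CCc4ccccc43)c2cc1NC(=O)C=C(C)C`: 6270 nM
compound 2 `C/C=C/C(=O)Nc1cc2c(N3CCc4ccccc43)ncnc2cc1OC`: 8290 nM
compound 3 `COc1cc2ncnc(N3CCCc4ccccc43)c2cc1NC(=O)C=C(C)C`: 5410 nM

Compounds 1 and 2 share one core and differ only in the amide side chain. Compound 3 carries a different core; the difference between the core of compound 1 and the core of compound 3 is not broken down here. In this assay the three numbers sit close together, and none of the gaps between them exceeds the usual scatter, so no order among compounds 1, 2 and 3 is claimed.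

Within the data shown here, the one single-point change with a measured outcome is prop-1-en-1-yl in place of 2-methylprop-1-en-1-yl on a carbonyl carbon, which gave a 1.3-fold higher number from compound 1 to compound 2 (0.12 log units; within the scatter).

Compound 4 `C/C=C/C(=O)Nc1cc2c(N3CCCc4ccccc43)ncnc2cc1OC` has not been measured. Relative to compound 3 it carries the same kind of change, on the same place: prop-1-en-1-yl in place of 2-methylprop-1-en-1-yl on a carbonyl carbon. Among the measured compounds shown here, the only information bearing on compound 4 is the measured pair of compounds 1 and 2 together with the value of compound 3, 5410 nM.

On that basis the step from compound 3 to compound 4 is expected to be small, a 1.3-fold higher number from compound 3 to compound 4 (0.11 log units; within the scatter), because the matching step a 1.3-fold higher number from compound 1 to compound 2 (0.12 log units; within the scatter) stayed within the scatter. For compound 4 in this assay the estimated value is 7000 nM, expected to fall between 3800 nM and 13000 nM.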

Compound 4, half-maximal inhibitory concentration: 8190 nM
Compound 4: the middle estimate sits 1.2-fold (0.07 log units) below what was measured; low and high end bracket the measured number.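

In this assay, prop-1-en-1-yl in place of 2-methylprop-1-en-1-yl on a carbonyl carbon gives a 1.5-fold higher number from compound 3 to compound 4 (0.18 log units; within the scatter). Set beside the earlier pair, the change reads alike on both cores: the same change on two cores in this assay, a 1.3-fold higher number (0.12 log units; within the scatter) from compound 1 to compound 2 and a 1.5-fold higher number (0.18 log units; within the scatter) from compound 3 to compound 4, 1.1-fold (0.06 log units) apart, within the scatter of two such steps. This shows that the step stays small on these two cores, but with both steps and the gap between them inside the scatter, it shows no real effect of the change and gives no basis for expecting the same on any further core.

Open, as far as these compounds go, is how an amine, a carboxylic acid or a longer chain would read on the same carbonyl carbon, since only 2-methylprop-1-en-1-yl and prop-1-en-1-yl appear there. Also open is whether the change would stay this small on a core giving much lower numbers, because all four compounds shown lie close together on this read-out.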